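Replacing pyridin-3-yl with 3-hydroxyphenyl in a cytotoxicity series

A few compounds are considered here, and "the series" means these few. Any claim that something is new, unique, unknown or untested is made for them only; others in the source may bear on it.

Of the compounds shown here, two of the shared core have been measured in a functional assay on MDA-MB-231 cells (Homo sapiens) for cytotoxicity, read by MTT assay, with a stated time of 48 h; a lower number here means a stronger inhibitor, a higher number a weaker inhibitor. Compound 1 `O=C(/C=C/c1ccc2c(c1)B(O)OC2)c1cccnc1` gives 11400 nM in this assay, the higher of the two numbers recorded. Compound 2 `CCc1ccc(C(=O)/C=C/c2ccc3c(c2)B(O)OC3)cc1` gives 9800 nM in this assay; the two values lie within the scatter of each other, so no order between compound 1 and compound 2 can be read from them. Within the data shown here, no step between measured compounds that differ in one place is available, and the two compounds differ from each other in more than one place.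

Compound 3 `O=C(/C=C/c1ccc2c(c1)B(O)OC2)c1cccc(O)c1` is the next compound to be measured in this assay. It differs from compound 1 by 3-hydroxyphenyl in place of pyridin-3-yl on a carbonyl carbon. Among the measured compounds shown here, with no single-point step recorded, nothing in the numbers so far shows how the group on the carbonyl carbon moves the read-out; both measured compounds sit close together despite carrying different groups there. The expected step from compound 1 to compound 3, a 1.2-fold lower number from compound 1 to compound 3 (0.08 log units; within the scatter), is therefore small and within the scatter, with no clear direction. Compound 3 is expected to give 9500 nM in this assay, between 3500 nM and 26000 nM.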

Compound 3, half-maximal inhibitory concentration: 2700 nM
Compound 3: the middle estimate sits 3.5-fold (0.55 log units) above what was measured; measured number below the stated range.
By their numbers in this assay, from the lowest: compound 3; then compounds 2 and 1 (each within the scatter of the next).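

In this assay, among these compounds, 3-hydroxyphenyl in place of pyridin-3-yl on a carbonyl carbon gives a 4.2-fold lower number from compound 1 to compound 3 (0.63 log units; beyond the scatter) and provides the first single-place step, modest in size but readable. The earlier pair could not show this: its two members differ in more than one place and lie within the scatter of each other, whereas the read-out is now seen to respond to a change in the aromatic ring at this position. The step replaces a ring with one hetero atom and no hydrogen-bond donor by a carbon-only ring with one hydrogen-bond donor, but no measurement shown separates these differences, and no supporting data explain the step.

Left open is whether the hydroxyl group or the loss of the ring nitrogen accounts for the step; unsubstituted phenyl and 3-methoxyphenyl on the same carbonyl carbon would separate these two changes. Also open, on these data alone, is whether the result is specific to the hydroxyl group, which 3-aminophenyl would test, and whether 4-hydroxyphenyl would give a similar step.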